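Cytotoxicity notes on the sulfonate series, compound 4 pending

The compounds below may be only part of what the source reports. "The series", "measured", "known", "first", "only" and "open" are said of these compounds alone.

The series shares the core of compound 1 `CCC1(Cc2ccccc2)OS(=O)(=O)C=C1OC`; compound 2 `CCC1(Cc2ccccc2)OS(=O)(=O)C=C1OCC1CCCCC1` and compound 3 `CCC1(Cc2ccccc2)OS(=O)(=O)C=C1OCc1ccc(Cl)cc1` carry cyclohexyl and 4-chlorophenyl on the saturated chain carbon bound to the oxygen on the unsaturated carbon. In an ADME assay on HEL cells (Homo sapiens) for cytotoxicity, with a stated time of 3 days (a lower number here means that less compound is tolerated, a higher number that more compound is tolerated), compound 1 gives > 200000 nM, which is a limit of the assay and not a number. In this assay compound 2 gives > 200000 nM, again a limit. In this assay compound 3 gives > 200000 nM, also a limit. Consequently the steps a step that the two limits leave unreadable from compound 1 to compound 2, a step that the two limits leave unreadable from compound 1 to compound 3 and a step that the two limits leave unreadable from compound 2 to compound 3 cannot be sized; all three values sit at the limit of > 200000 nM in this assay, at which 3 of the 3 values shown sit. Compound 4 `CCC1(Cc2ccccc2)OS(=O)(=O)C=C1OCc1ccc(Br)cc1` differs from compound 3 by bromo in place of chloro on an aromatic carbon. No measured step can be read for guidance, yet every measured change on that saturated chain carbon left the value at the limit. The expectation for compound 4 in this assay is therefore no step beyond the scatter, a number no higher from compound 3 to compound 4 (the limit leaves the size open), with the result most likely again reported only as a limit. The estimate for compound 4 is 200000 nM, ranging from 100000 nM to 600000 nM.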

Compound 4, half-maximal cytotoxic concentration: 171000 nM
The estimate for compound 4 lay 1.2-fold (0.07 log units) above the measured number; measured number inside the range.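

In this assay, bromo in place of chloro on an aromatic carbon, para to a large group, gives the first value in the series that is a number and not a limit, while the other compounds stay at the limit: the limit of > 200000 nM in this assay, at which 3 of the 4 values shown sit.
The change at this position reads as an at least 1.1-fold lower number from compound 3 to compound 4 (0.06 log units; that floor lies within the scatter), and the changes on the saturated chain carbon read as an at least 1.1-fold lower number from compound 2 to compound 4 (0.06 log units; that floor lies within the scatter) and an at least 1.1-fold lower number from compound 1 to compound 4 (0.06 log units; that floor lies within the scatter).
Each of these is only a floor within the scatter, so the result does not set compound 4 apart from the other three compounds.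

Going by these compounds, the full size of each step remains open, and with it whether exchanging chloro for bromo matters at all. Also open, on these data alone, is how an amine or a carboxylic acid in place of bromo on that aromatic carbon would read in this assay.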